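Diethylcarbamoyl in place of phenyl: notes on the series

The compounds below may be only part of what the source reports. "The series", "measured", "known", "first", "only" and "open" are said of these compounds alone.

Of the compounds shown here, three on the shared core have been measured in a functional assay on the whole organism with Rattus norvegicus as the target; a higher number here means that more compound is needed for the effect, a lower number that less compound is needed. Compound 1 `CCCn1c(=N)sc2cc(OC(F)(F)F)ccc21` gives 4.5 mg/kg, and compound 2 `N#CCn1c(=N)sc2cc(OC(F)(F)F)ccc21` gives 3.5 mg/kg. Compound 3 `N=c1sc2cc(OC(F)(F)F)ccc2n1Cc1ccccc1` gives > 10 mg/kg, which is a limit and not a number. Compound 3 alone sits at the limit of > 10 mg/kg in this assay, at which 1 of the 3 values shown sits.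

Compound 4 `CCN(CC)C(=O)Cn1c(=N)sc2cc(OC(F)(F)F)ccc21` carries diethylcarbamoyl in place of phenyl on a saturated chain carbon bound to an aromatic nitrogen.

Within the data shown here, the measured steps at this same place are the only guide. a 1.3-fold lower number from compound 1 to compound 2 (0.11 log units; within the scatter) stays within the scatter. an at least 2.2-fold higher number from compound 1 to compound 3 (0.34 log units; beyond the scatter) and an at least 2.8-fold higher number from compound 2 to compound 3 (0.45 log units; beyond the scatter) both lie beyond it, and both are at least modest. Among the measured compounds shown here, no measured step brings in diethylcarbamoyl, so the guide is indirect. Like compound 1 at 4.5 mg/kg and compound 2 at 3.5 mg/kg, compound 4 has no phenyl on the chain, and a modest move to a lower number in this assay is therefore expected. The expected step is an at least 1.6-fold lower number from compound 3 to compound 4 (0.22 log units; that floor lies within the scatter), and a second reading at the limit remains possible. For compound 4 the estimated value is 6 mg/kg, with an expected range of 2.5 mg/kg to 14 mg/kg.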

Compound 4, dose for half-maximal effect: 9 mg/kg
Estimate against measurement, compound 4: 1.5-fold (0.18 log units) below; measured number inside the range.
By their numbers in this assay, from the lowest: compounds 2, 1 and 4 (each within the scatter of the next, the first and the last beyond it). At a limit, above all of these: compound 3.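

Compound 3 remains a limit and not a number, the only such reading among the four compounds: the limit of > 10 mg/kg in this assay, at which 1 of the 4 values shown sits.

In this assay, an at least 1.1-fold lower number from compound 3 to compound 4 (0.04 log units; that floor lies within the scatter), so this comparison shows no clear separation between diethylcarbamoyl and phenyl at this position on a saturated chain carbon bound to an aromatic nitrogen. What compound 4 adds is a numerical reading for a larger chain group without a ring, and it shows that such groups do not all read alike here: a 2.6-fold higher number from compound 2 to compound 4 (0.41 log units; beyond the scatter), which separates diethylcarbamoyl from cyano, whereas a 2.0-fold higher number from compound 1 to compound 4 (0.30 log units; within the scatter), which gives no separation from ethyl.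

The compounds shown do not tell whether the carbonyl or the two ethyl groups on the amide nitrogen set the reading of compound 4, a question that a plain carbamoyl, dimethylcarbamoyl or a carboxylic acid at this place would address. As far as these compounds go, it also stays open whether a ring as such goes with the limit seen for compound 3, or whether a saturated ring such as cyclohexyl, or an amine on a longer chain, would read differently.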